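Chain extension in an ester series, cytotoxicity

The source may report more compounds than this note shows. Statements on the series, on what has been measured and on what is new or still open speak of the compounds shown alone.

Measured:
compound 1 `CCCCCCCCCCCCCCCOC(=O)CCC(=O)N1CCN(CCCOc2cc3c(Nc4ccc(F)c(Cl)c4)ncnc3cc2OC)CC1`: 92%
compound 2 `CCCCCCCCCCCCCCCCCOC(=O)CCC(=O)N1CCN(CCCOc2cc3c(Nc4ccc(F)c(Cl)c4)ncnc3cc2OC)CC1`: 95.7%

In a functional assay on A549 cells (Homo sapiens) for cytotoxicity, read by MTT assay, with a stated time of 24 h, tested at 10 uM (a higher number here means a weaker effect of the compound at the concentration tested, a lower number a stronger effect), compound 1 and compound 2 lie within the scatter of each other; the step of a number 3.7 percentage points higher from compound 1 to compound 2 (within the scatter) is the only one known. Compound 3 `CCCCCCCCCCCCCCCCCCOC(=O)CCC(=O)N1CCN(CCCOc2cc3c(Nc4ccc(F)c(Cl)c4)ncnc3cc2OC)CC1` carries the change methyl in place of hydrogen on a saturated chain carbon, ten or more bonds along the chain from an oxygen next to a carbonyl group on compound 2. Among the measured compounds shown here, the one step that bears on it, a number 3.7 percentage points higher from compound 1 to compound 2 (within the scatter), is chain extension of the same kind and stayed within the scatter, so a step of no more than the scatter is expected in this assay for compound 3, that is a number 0.3 percentage points higher from compound 2 to compound 3 (within the scatter). Compound 3 is estimated at 96%, range 85% to 102%.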

Compound 3, a percentage reported as activity, at one concentration (the size of the read-out at that concentration, not a potency): 94.8%
Beside the measured number, compound 3's estimate is 1.2 percentage points above it; the measured number falls inside the stated range.
By their numbers in this assay, from the lowest: compounds 1, 3 and 2 (each within the scatter of the next).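

In this assay, methyl in place of hydrogen on a saturated chain carbon, ten or more bonds along the chain from an oxygen next to a carbonyl group, gives a number 0.9 percentage points lower from compound 2 to compound 3 (within the scatter), and propyl at that place gives a number 2.8 percentage points higher from compound 1 to compound 3 (within the scatter). Both steps stay within the scatter, as the earlier ethyl step did, so the three esters cannot be ordered in this assay. No measured evidence is available to explain this flat read-out.

Still open, as far as these compounds go, is whether a much shorter chain would shift the read-out in this assay. An amine or a carboxylic acid at the chain end also remains untested among the compounds shown.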